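A few compounds are considered here, and "the series" means these few. Any claim that something is new, unique, unknown or untested is made for them only; others in the source may bear on it.

Working notes, values from a functional assay on HeLa cells (Homo sapiens) for antiproliferative activity, read by MTT assay, with a stated time of 72 h; a higher number here means a weaker inhibitor, a lower number a stronger inhibitor:

- compound 1 `COc1cc(C(=O)c2sc3ccccc3c2-c2ccc(C)cc2)cc(OC)c1OC`: 3700 nM
- compound 2 `COc1cc(C(=O)c2sc3ccccc3c2Nc2ccc(Cl)cc2)cc(OC)c1OC`: 3700 nM
- compound 3 `COc1cc(C(=O)c2sc3ccccc3c2Nc2ccc(C)cc2)cc(OC)c1OC`: not yet measured

Compound 1 and compound 2 stand level, with compound 2 at 3700 nM. Compound 3 differs from compound 2 by methyl in place of chloro on an aromatic carbon, para to a large group. Going by the values given here, only one measured step bears on this, and only in part, as it also brings in the amino: no change at the digits printed from compound 1 to compound 2 (within the scatter). No step beyond the scatter is therefore expected in this assay. The expected change is a 1.2-fold lower number from compound 2 to compound 3 (0.09 log units; within the scatter). For compound 3 the estimate is 3000 nM, with an expected range of 900 nM to 9000 nM.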

Compound 3, half-maximal inhibitory concentration: 3500 nM
Beside the measured number, compound 3's estimate is 1.2-fold (0.07 log units) below it; the measured number falls inside the stated range.
By their numbers in this assay, from the lowest: compounds 3, 1 and 2 (each within the scatter of the next).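

In this assay, methyl in place of chloro on an aromatic carbon, para to a large group, gives a 1.1-fold lower number from compound 2 to compound 3 (0.02 log units; within the scatter) and so tests this place on its own. With the para methyl kept, (4-methylphenyl)amino in place of 4-methylphenyl gives a 1.1-fold lower number from compound 1 to compound 3 (0.02 log units; within the scatter) and so isolates the amino, which the earlier step carried together with the chloro. Nothing on hand explains either result.

Going by these compounds, only chloro and methyl are compared at this place, so an amine or a carboxylic acid there remains open. On these data alone, a longer chain in place of the amino is also open.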